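Swapping Ethoxy for Methyl: An Expected Whole-Animal Result

The source may report more compounds than this note shows. Statements on the series, on what has been measured and on what is new or still open speak of the compounds shown alone.

Three compounds were measured in a functional assay on the whole organism for inhibition, with Rattus norvegicus as the target (on this read-out lower numbers stand for an effect already at smaller amounts and higher numbers for an effect only at larger amounts of compound), and each stopped at a limit of the assay rather than at a number:

Compound 1, `CC1CC/C(=N\Nc2cccc(Br)c2)c2ncc(C(=O)O)c(=O)n21`, gives the limit > 320 umol/kg.
Compound 2, `CC1CC/C(=N\Nc2ccc(Br)cc2)c2ncc(C(=O)O)c(=O)n21`, gives the limit > 1000 umol/kg.
Compound 3, `CCOc1ccccc1N/N=C1\CCC(C)n2c1ncc(C(=O)O)c2=O`, gives the limit > 1000 umol/kg.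

Compound 3 therefore stands at the limit of > 1000 umol/kg in this assay, at which 2 of the 3 values shown sit. Compound 1 stands at the limit of > 320 umol/kg in this assay, at which 1 of the 3 values shown sits. Among the measured compounds shown here, the single measured step between neighbours, a step that the two limits leave unreadable from compound 1 to compound 2, is a move between two limits and so carries no readable size.

Compound 4, `Cc1ccccc1N/N=C1\CCC(C)n2c1ncc(C(=O)O)c2=O`, differs from compound 3 by methyl in place of ethoxy on an aromatic carbon. For the measured compounds named here, no measured step touches this kind of change; the one step available concerns a bromine position and is unreadable in any case. The expected step is therefore a number no higher from compound 3 to compound 4 (the limit leaves the size open), meaning no change beyond the scatter. Compound 4 is estimated at 1000 umol/kg, within a range from 300 umol/kg to 3000 umol/kg, and most probably the assay would again report only a limit.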

Compound 4, dose for 50% inhibition: > 100 umol/kg
Compound 4: no number, only a limit (the forecaster's own chance of this, stated with the estimate: 80%); the middle value lies beyond the limit too.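

In this assay, among the compounds shown here, compound 4 also stops at a limit, like compound 1, compound 2 and compound 3, so no step to compound 4 can be read. The compounds shown leave open what dose of any of them gives the effect in this assay, and whether swapping these groups changes it.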